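The source may hold more compounds than are shown below. What is called first, only, known or untested is meant among the compounds shown, and "the series" means these compounds.

In a physicochemical assay for solubility, measured as kinetic solubility (a higher number here means a more soluble compound, a lower number a less soluble compound), compound 1 `CCC/N=C1\S/C(=C\c2ccc(O)c(Cl)c2)C(=O)N1C1CCS(=O)(=O)CC1` gives 75000 nM. Compound 2 `Cc1ccccc1N1C(=O)/C(=C/c2ccc(O)c(Cl)c2)S/C1=N\CCO` gives > 250000 nM, which is a limit of the assay. Compound 3 `CCC/N=C1\S/C(=C\c2ccc(O)c(Cl)c2)C(=O)N1C1CCN(C)C(=O)C1` gives > 250000 nM, also a limit and not a number. Compound 3 therefore stands at the limit of > 250000 nM in this assay, at which 2 of the 3 values shown sit.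

Compound 4 `CCC/N=C1\S/C(=C\c2ccc(O)c(Cl)c2)C(=O)N1c1ccccc1O` differs from compound 3 by 2-hydroxyphenyl in place of 1-methyl-2-oxopiperidin-4-yl on an amide-type nitrogen in a ring. In short, 2-hydroxyphenyl comes in place of 1-methyl-2-oxopiperidin-4-yl on an amide-type nitrogen in a ring.

Within the data shown here, one measured step bears on this place: an at least 3.3-fold higher number from compound 1 to compound 3 (0.52 log units; beyond the scatter). Among the measured compounds shown here, that step ends at a limit, so its full size stays open, and no measured step with the same chain brings an aromatic ring to this place. Removing 1-methyl-2-oxopiperidin-4-yl is the reverse of the change in that step, so a lower number in this assay is expected, of about that size or somewhat larger. The expected change is an at least 4.1-fold lower number from compound 3 to compound 4 (0.61 log units; beyond the scatter). Compound 4 is estimated at 60000 nM, with an expected range of 15000 nM to 220000 nM.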

Compound 4, solubility: 220000 nM
For compound 4 the middle estimate is 3.7-fold (0.56 log units) below the measured one; the range from low to high includes it.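

In this assay, the first aromatic ring at this place, on the amide-type nitrogen in a ring, can be read against a non-aromatic one: 2-hydroxyphenyl in place of 1,1-dioxothian-4-yl gives a 2.9-fold higher number from compound 1 to compound 4 (0.47 log units; beyond the scatter). Against 1-methyl-2-oxopiperidin-4-yl, the same group gives an at least 1.1-fold lower number from compound 3 to compound 4 (0.05 log units; that floor lies within the scatter), so this floor does not set the two groups apart. The true size of that step stays open at the limit that compound 3 holds: the limit of > 250000 nM in this assay, at which 2 of the 4 values shown sit.

Still open, from the compounds shown here alone, is how much of the step from 1,1-dioxothian-4-yl belongs to the aromatic ring and how much to its hydroxy group, which plain phenyl at this place would separate. Going by these compounds, an amine or a carboxylic acid on that ring is also open, as is any order between 2-hydroxyphenyl and 1-methyl-2-oxopiperidin-4-yl.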